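Ring replaces chain on the core nitrogen substituent

A few compounds are considered here, and "the series" means these few. Any claim that something is new, unique, unknown or untested is made for them only; others in the source may bear on it.

Working notes on a small set of amide-linked kinase inhibitors built around a shared bicyclic core, all carrying the same pyrazole and methoxybenzyl-type amide side.

Compound 1 `COc1cccc(CNC(=O)c2cn(C)c3nc(-c4cn[nH]c4)ccc23)c1` is the reference. In an assay on isolated protein for inhibition of Rho-associated protein kinase 1 (Homo sapiens) (a higher number here means a weaker inhibitor, a lower number a stronger inhibitor), compound 1 gives < 1 nM, which is a limit of the assay rather than a number (the limit of < 1 nM in this assay, at which 1 of the 3 values shown sits). Compound 2 `COc1cccc(CN(C)C(=O)c2cc3ccc(-c4cn[nH]c4)nc3[nH]2)c1` gives 27 nM in this assay. Compound 3 `COc1cccc(CNC(=O)c2cc3ccc(-c4cn[nH]c4)nc3n2CCN(C)C)c1` gives 243 nM in this assay, the highest of the two numbers shown; its nearest neighbour by value is compound 2, whose number lies lower by a margin beyond the usual scatter. Among the measured compounds shown here, no single-point step between measured compounds is available, so the set gives only these isolated readings.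

Compound 4 `COc1cccc(CNC(=O)c2cc3ccc(-c4cn[nH]c4)nc3n2CC2CC2)c1` has not been measured in this assay. It differs from compound 3 in one place: cyclopropyl in place of (dimethylamino)methyl on a saturated chain carbon bound to an aromatic nitrogen. The change is at the substituent on the core aromatic nitrogen, at the carbon bound to that nitrogen.

For the measured compounds named here, with no comparable measured step to lean on, the expected step is a modest one, and the estimated change is a 1.6-fold lower number from compound 3 to compound 4 (0.21 log units; within the scatter). For compound 4 the estimated result in this assay is 150 nM, with a range from 40 nM to 600 nM.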

Compound 4, half-maximal inhibitory concentration: 280 nM
Estimate against measurement, compound 4: 1.9-fold (0.27 log units) below, and the stated range covers the measured number.
By their numbers in this assay, from the lowest: compound 2; then compounds 3 and 4 (each within the scatter of the next). At a limit, below all of these: compound 1.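

In this assay, among the compounds shown here, exchanging 2-(dimethylamino)ethyl for cyclopropylmethyl on the core aromatic nitrogen reads as a 1.2-fold higher number from compound 3 to compound 4 (0.06 log units; within the scatter), the first step in the set that isolates a single place. The earlier compounds shown here gave only separate readings, whereas this pair shows that the two substituents cannot be told apart in this assay, even though the leaving group carries a nitrogen and a hydrogen-bond acceptor and the entering group carries a three-membered carbon ring instead. Nothing available bears on why the two substituents read alike.

Going by these compounds, whether a chain ending in a carboxylic acid, a longer chain carrying a morpholine, or a larger ring such as cyclohexyl on the same carbon would read apart from compound 3 and compound 4 remains open. For the compounds shown here, no single-place step links either of these two compounds to compound 1 or compound 2, so the differences among those readings cannot be assigned to any one part of the structure.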